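Benzyl to Phenylcarbamoyl on the Sulfonamide Nitrogen

The source may hold more compounds than are shown below. What is called first, only, known or untested is meant among the compounds shown, and "the series" means these compounds.

Of the compounds shown here, three sharing one core have been measured in a functional assay on the whole organism (trachea) with Rattus norvegicus as the target; a higher number here means a larger maximal response, a lower number a smaller maximal response. Compound 1 `CC1(C)C=C(n2ccccc2=O)c2cc(S(=O)(=O)NCCO)ccc2O1` gives 87.9%. Compound 2 `CC1(C)C=C(n2ccccc2=O)c2cc(S(=O)(=O)NCc3ccccc3)ccc2O1` gives 77.5%, and compound 3 `CN(c1ccccc1)S(=O)(=O)c1ccc2c(c1)C(n1ccccc1=O)=CC(C)(C)O2` gives 86.5%. Compound 2 stands lowest of the three numbers: the step of a number 10.4 percentage points lower from compound 1 to compound 2 (beyond the scatter) lies beyond the scatter, whereas the step of a number 9 percentage points higher from compound 2 to compound 3 (within the scatter) lies within it, as does the step of a number 1.4 percentage points lower from compound 1 to compound 3 (within the scatter).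

Compound 4 `CC1(C)C=C(n2ccccc2=O)c2cc(S(=O)(=O)NC(=O)Nc3ccccc3)ccc2O1` differs from compound 2 at the sulfonamide nitrogen: phenylcarbamoyl in place of benzyl on a sulfonamide nitrogen. Going by the values given here, no measured step introduces a phenylcarbamoyl group, so the measured steps bear on this change only indirectly. They show that exchanging the group on the sulfonamide nitrogen has moved the maximal response modestly at most, the largest such move being a number 10.4 percentage points lower from compound 1 to compound 2 (beyond the scatter), while the exchange of benzylamino for methyl(phenyl)amino gave a number 9 percentage points higher from compound 2 to compound 3 (within the scatter), within the scatter. Because compound 2 sits at 77.5%, the lowest of the three, a small upward move, or none beyond the scatter, is expected in this assay. The step expected is a number 5.5 percentage points higher from compound 2 to compound 4 (within the scatter). Compound 4 is estimated to reach 83%, with a range from 70% to 96%.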

Compound 4, largest response reached (Emax), in percent of the reference or control that the assay uses: 99.5%
Estimate against measurement, compound 4: 16.5 percentage points below, outside the stated range (above it).
By their numbers in this assay, from the lowest: compounds 2, 3 and 1 (each within the scatter of the next, the first and the last beyond it); then compound 4.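

In this assay, phenylcarbamoyl in place of benzyl on a sulfonamide nitrogen gives a number 22 percentage points higher from compound 2 to compound 4 (beyond the scatter), which shows that this position can carry a change that clearly separates a compound from all the others shown. The separation does not depend on benzyl as the point of comparison: (phenylcarbamoyl)amino in place of methyl(phenyl)amino on the sulfonyl sulfur gives a number 13 percentage points higher from compound 3 to compound 4 (beyond the scatter), and phenylcarbamoyl in place of 2-hydroxyethyl gives a number 11.6 percentage points higher from compound 1 to compound 4 (beyond the scatter), so compound 4 has the largest maximal response of the four, whereas compound 3 could not be separated from either compound 1 or compound 2. Nothing available accounts for this rise in the response.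

The compounds shown do not tell whether the rise needs the whole phenylcarbamoyl group, as an acetyl group or a cyclohexylcarbamoyl group on the sulfonamide nitrogen would test. They also leave open whether it survives a methyl(phenyl)carbamoyl group, in which a methyl replaces the hydrogen on the nitrogen of the phenylcarbamoyl, or a chlorine on its phenyl ring.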